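Replacing a Nitrile With a Carboxylic Acid on the Chain

The source may report more compounds than this note shows. Statements on the series, on what has been measured and on what is new or still open speak of the compounds shown alone.

Measured so far:
Compound 1 `COc1ccc(-c2cc3c(OC)cc(OC)cc3n(C)c2=O)cc1`: 10000 nM
Compound 2 `CCOC(=O)Cn1c(=O)c(-c2ccc(OC)cc2)cc2c(OC)cc(OC)cc21`: 10000 nM
Compound 3 `COc1ccc(-c2cc3c(OC)cc(OC)cc3n(CC#N)c2=O)cc1`: 10000 nM

In a functional assay on A-427 cells (Homo sapiens) for cytotoxicity, read by colorimetric assay and MTT assay (on this read-out higher numbers stand for weaker inhibition and lower numbers for stronger inhibition), compound 1 gives 10000 nM, compound 2 gives 10000 nM and compound 3 gives 10000 nM. Compound 3 therefore stands level with the other two: the steps of no change at the digits printed from compound 1 to compound 3 (within the scatter) and no change at the digits printed from compound 2 to compound 3 (within the scatter) both lie within the scatter, as does no change at the digits printed from compound 1 to compound 2 (within the scatter).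

Compound 4 `COc1ccc(-c2cc3c(OC)cc(OC)cc3n(CC(=O)O)c2=O)cc1` differs from compound 3 in one place: carboxy in place of cyano on a saturated chain carbon bound to an aromatic nitrogen. Every measured step changes the same saturated chain carbon bound to an aromatic nitrogen, exchanging hydrogen, ethoxycarbonyl and cyano, and none of them moved the read-out beyond the scatter. A carboxy in that same place is expected to behave alike, so for compound 4 a step of no change at the digits printed from compound 3 to compound 4 (within the scatter) is expected, meaning no change beyond the scatter. Compound 4 is estimated at 10000 nM, with a range from 5000 nM to 20000 nM.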

Compound 4, half-maximal inhibitory concentration: 10000 nM
Estimate against measurement, compound 4: no gap at the digits printed; low and high end bracket the measured number.
By their numbers in this assay, from the lowest: compounds 1, 2, 3 and 4 (each within the scatter of the next).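

With a carboxy group on the chain, hydrogen-bond donor included where cyano has none, this assay shows no change at the digits printed from compound 3 to compound 4 (within the scatter) and the read-out stays put. Cutting the ethyl from the ester shows no change at the digits printed from compound 2 to compound 4 (within the scatter) and adding carboxy to the bare methyl shows no change at the digits printed from compound 1 to compound 4 (within the scatter), so hydrogen, ethoxycarbonyl, cyano and carboxy on this saturated chain carbon bound to an aromatic nitrogen all read alike, and none of the four compounds goes against that. Nothing available explains why this position is so insensitive.

Still open, from the compounds shown here alone, is whether any group here can lower the number, such as an amine, a primary amide or a longer chain ending in carboxy. Also open, going by these compounds, is whether changes elsewhere on the shared core would move the value.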